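The source may hold more compounds than are shown below. What is called first, only, known or untested is meant among the compounds shown, and "the series" means these compounds.

Compound 1: `Cc1ccc(-c2nnc(Nc3csc(-c4ccccc4)c3)s2)cc1` — "not determined" (no result reported) in a functional assay on Hs 683 cells (Homo sapiens) for inhibition, read by colorimetric assay and MTT assay, with a stated time of 72 h; on this read-out higher numbers stand for weaker inhibition and lower numbers for stronger inhibition.
Compound 2: `COc1ccc(-c2nnc(Nc3csc(-c4ccccc4)c3)s2)cc1` — 5000 nM in this assay.
Compound 3: `COc1ccc(-c2nnc(Nc3csc(-c4ccc(C)cc4)c3)s2)cc1` — "not determined" (no result reported) in this assay.

Three compounds were put through this assay, and only one of them came back with a number. Compound 1 and compound 3 were tested, but no value was reported for either, so nothing can be said about how they compare. Compound 2 therefore stands alone: in this assay compound 2 gives 5000 nM, and this is the single fixed point against which any new member of the series can be judged.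

The next compound, compound 4, has the structure `Oc1ccc(-c2nnc(Nc3csc(-c4ccccc4)c3)s2)cc1`. It differs from compound 2 in one place: hydrogen in place of methyl on an oxygen on an aromatic ring. Everything else in the shared core of compound 2 is kept.

Within the data shown here, because no pair of measured compounds differs in just one place, there is no step in this assay to copy from. A change of this kind, a small group swapped for a hydrogen at the edge of the molecule, is expected to shift the result by no more than the usual scatter, with no clear direction. The expected step from compound 2 to compound 4 in this assay is no change at the digits printed from compound 2 to compound 4 (within the scatter). Compound 4 is accordingly estimated at 5000 nM in this assay, within a range from 1500 nM to 15000 nM.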

Compound 4, half-maximal inhibitory concentration: 26000 nM
Beside the measured number, compound 4's estimate is 5.2-fold (0.72 log units) below it, outside the stated range (above it).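

In this assay, the methyl on the oxygen turns out to matter: going from methoxy to hydroxy gives a 5.2-fold higher number from compound 2 to compound 4 (0.72 log units; beyond the scatter), a step beyond the scatter. Among these compounds, this is the first step that can be read, and it shows that a change of a single small group on this aromatic ring can move the result, with the 4-methoxyphenyl compound giving the lower number and so the stronger inhibition of the pair. Nothing available explains why the step runs in this direction.

Among the compounds shown here, only two groups at this place carry numbers so far, so one step cannot show whether the trend would hold for other groups, and how an amine, a fluorine or a longer chain on the oxygen such as ethoxy would compare remains open. From the compounds shown here alone, the steps involving compound 1 and compound 3 cannot be read, so it also remains open whether the same change would have a similar effect with a different group on the other aromatic ring.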